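This account rests on a few compounds, and the source may have more. Where it says the series, first, only, none or still open, it means among the compounds named here.

Of the compounds shown here, two have numbers so far. Compound 1 `Nc1ncc(Cc2cc(CO)cc(CO)c2)c(N)n1` and compound 2 `COCCOc1ccc(Cc2cnc(N)nc2N)cc1` share the same core and differ in the substitution of the carbon-only six-membered ring. In a functional assay on L5178Y cells (Mus musculus) for inhibition (on this read-out higher numbers stand for higher potency (the scale is a negative logarithm) and lower numbers for lower potency), compound 1 gives 3.79, while compound 2 gives 4.77, the higher of the two numbers and a gap from compound 1 that lies beyond the usual scatter. Going by the values given here, no step between compounds differing in a single place is available, so nothing can yet be said about which part of the structure drives that gap.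

Compound 3 `Nc1ncc(Cc2ccc(Br)cc2)c(N)n1` is the next compound awaiting a number in this assay. Relative to compound 2 the change is bromo in place of 2-methoxyethoxy on an aromatic carbon. Because compound 2 stands at 4.77 and the substituent that enters is a single heavy atom without acceptors, the expectation is a modest fall, estimated as a number 0.27 log units lower from compound 2 to compound 3 (within the scatter), not clearly beyond the scatter. The estimate for compound 3 in this assay is 4.5, with a range from 3.8 to 5.2.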

Compound 3, logarithm of the reciprocal of the active concentration, log(1/C): 5.38
Compound 3: the middle estimate sits 0.88 log units below what was measured; the measured number lies above the stated range.
By their numbers in this assay, from the lowest: compound 1; then compound 2; then compound 3.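

In this assay the series now has its first single-place step, a number 0.61 log units higher from compound 2 to compound 3 (beyond the scatter) with bromo in place of 2-methoxyethoxy on an aromatic carbon, para to a group of 9 heavy atoms. At this position, the 2-methoxyethoxy chain, with 5 heavy atoms and 2 hydrogen-bond acceptors, is therefore not required for a higher number: a single bromine atom with no hydrogen-bond acceptors gives more in this read-out. No measured property of these compounds accounts for the size or direction of this change.

A single pair cannot separate a gain from bromo itself from a loss caused by the 2-methoxyethoxy chain, so methoxy, methyl, chloro or an amine at the same position would be needed to tell these readings apart. On these data alone, it also remains open whether bromo gives a comparable step on other substitution patterns of the carbon-only ring, such as the pattern of compound 1, which differs from compound 3 in more than one place.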